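Swapping a nitrile chain for a dimethyl amide on the shared core

The source may hold more compounds than are shown below. What is called first, only, known or untested is meant among the compounds shown, and "the series" means these compounds.

Measured compounds:
Compound 1 `CC(=O)c1cc(C=O)c(OCCCCC#N)cc1O` gives 3% in an assay on isolated protein for binding affinity to leukotriene B4 receptor 1 (Homo sapiens), tested at 1 uM; on this read-out higher numbers stand for more inhibition at the one concentration tested (going by the name of the read-out) and lower numbers for less inhibition.
Compound 2 `C=CCc1cc(C(C)=O)c(O)cc1OCCCCCCCCC#N` gives 50% in this assay.
Compound 3 `CCc1cc(C(C)=O)c(O)cc1OCCCCCC(C)(C)C(=O)O` gives 73% in this assay.

Compound 2 stands second highest of the three numbers: compound 3 lies higher by a gap beyond the usual scatter, and compound 1 lies lower by a gap also beyond it. Compound 4 `C=CCc1cc(C(C)=O)c(O)cc1OCCCCCC(=O)N(C)C` has not yet been measured. It differs from compound 2 in one place: dimethylcarbamoyl in place of 3-cyanopropyl on a saturated chain carbon, five bonds along the chain from an oxygen on an aromatic ring. Among the measured compounds shown here, no measured pair shows this exact swap, so the outcome rests on the general picture that the chain end can vary while activity persists. Compound 4 is expected to change little from compound 2, with an estimated step of a number 5 percentage points lower from compound 2 to compound 4 (within the scatter) in this assay, a step not clearly beyond the scatter in either direction. Compound 4 is therefore estimated at 45%, within a range from 20% to 70%.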

Compound 4, a percentage reported as inhibition, at one concentration (the size of the read-out at that concentration, not a potency): 54%
Compound 4: the middle estimate sits 9 percentage points below what was measured; the range from low to high includes it.
By their numbers in this assay, from the lowest: compound 1; then compounds 2 and 4 (each within the scatter of the next); then compound 3.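

In this assay the first one-place comparison gives a number 4 percentage points higher from compound 2 to compound 4 (within the scatter), so at this saturated chain carbon, dimethylcarbamoyl can replace 3-cyanopropyl without a change that can be told from the scatter. The chain end can therefore switch from a nitrile to a dimethyl amide while this level of inhibition persists. No supporting measurement explains this match. Still open, on these data alone, is whether an amine or an unsubstituted amide at the same place would read alike. As far as these compounds go, a longer chain ending in dimethylcarbamoyl also remains open.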